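A few compounds are considered here, and "the series" means these few. Any claim that something is new, unique, unknown or untested is made for them only; others in the source may bear on it.

Measured in an ADME assay on microsomes from liver (Mus musculus, strain CD-1) for metabolic stability, read by LC-MS, tested at 2 uM; a lower number here means that the compound disappears faster, a higher number that the compound lasts longer:
compound 1 `CN1CC(NC(=O)c2ccncc2Nc2cc(-c3ccc4ccn(C)c4c3)c3nccnc3c2)CCC1=O`: 0.75 h
compound 2 `CC(=O)N1CCOC(CNC(=O)c2ccncc2Nc2cc(-c3ccc4ccn(C)c4c3)c3nccnc3c2)C1`: 0.217 h
compound 3 `CC(=O)N1CC(NC(=O)c2ccncc2Nc2cc(-c3ccc4ccn(C)c4c3)c3nccnc3c2)C1`: 0.817 h

Compound 3, at 0.817 h, sits at the top of this small set, level with compound 1: the difference is a 1.1-fold higher number from compound 1 to compound 3 (0.04 log units; within the scatter). The gap to the remaining compound is a 3.8-fold higher number from compound 2 to compound 3 (0.58 log units; beyond the scatter).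

The next change leads to compound 4 `CN1CCC(CNC(=O)c2ccncc2Nc2cc(-c3ccc4ccn(C)c4c3)c3nccnc3c2)C1`: (1-methylpyrrolidin-3-yl)methyl in place of 1-acetylazetidin-3-yl on an amide-type nitrogen. Among the compounds with values here, the nearest precedent is compound 2, the only measured compound whose group on the amide-type nitrogen is also a ring-bearing methyl, as seen in a 3.5-fold lower number from compound 1 to compound 2 (0.54 log units; beyond the scatter) and a 3.8-fold higher number from compound 2 to compound 3 (0.58 log units; beyond the scatter). Against that, a 1.1-fold higher number from compound 1 to compound 3 (0.04 log units; within the scatter) shows that one ring exchange left this assay unmoved. Within the data shown here, no measured compound lacks a carbonyl in this group, so the precedent is only partial. A modest fall is therefore expected, smaller than the gap to compound 2, and the expected change is a 2.3-fold lower number from compound 3 to compound 4 (0.37 log units; beyond the scatter). Compound 4 is estimated at 0.35 h, with an expected range of 0.13 h to 0.9 h.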

Compound 4, half-life: > 1 h
Compound 4: a limit, no number; the forecaster's own chance of this, stated with the estimate: 3%; at least 2.8-fold (0.45 log units) between middle value and limit.
By their numbers in this assay, from the lowest: compound 2; then compounds 1 and 3 (each within the scatter of the next). At a limit, above all of these: compound 4.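

In this assay, compound 4 is a limit and not a number: the limit of > 1 h in this assay, at which 1 of the 4 values shown sits.

The (1-methylpyrrolidin-3-yl)methyl group carries no carbonyl, unlike every earlier group on the amide-type nitrogen, and a ring-bearing methyl at this position is not tied to a short half-life, with an at least 4.6-fold higher number from compound 2 to compound 4 (0.66 log units; beyond the scatter). The other two steps, an at least 1.2-fold higher number from compound 3 to compound 4 (0.08 log units; that floor lies within the scatter) and an at least 1.3-fold higher number from compound 1 to compound 4 (0.12 log units; that floor lies within the scatter), have floors within the scatter, so they show no loss on this change, and no gain can be claimed from them.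

Open, going by these compounds, is how far compound 4 lies past its limit. Also open, on these data alone, is whether the difference from compound 2 follows the missing carbonyl or the change of ring; a (1-acetylpyrrolidin-3-yl)methyl group on the same nitrogen would bear on that.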